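A few compounds are considered here, and "the series" means these few. Any claim that something is new, unique, unknown or untested is made for them only; others in the source may bear on it.

Of the compounds shown here, two with a shared core have been measured in a functional assay on HCC 2998 cells (Homo sapiens) for inhibition, read by sulforhodamine B assay, with a stated time of 48 h, tested at 100 uM; a higher number here means a weaker effect of the compound at the concentration tested, a lower number a stronger effect. Compound 1 `COc1cc(Cl)cc(-c2nn(-c3cccc(NC(=O)Nc4ccc(Cl)c(C(F)(F)F)c4)c3)cc2-c2ccncc2)c1` gives -75% in this assay. Compound 2 `COc1cc(Cl)cc(-c2nn(-c3cccc(NC(=O)Nc4ccc(Cl)c(Cl)c4)c3)cc2-c2ccncc2)c1` gives -7% in this assay. For the measured compounds named here, compound 2 thus stands at the higher of the two numbers, and the single step recorded between them, a number 68 percentage points higher from compound 1 to compound 2 (beyond the scatter), lies beyond the scatter. Compound 3 `COc1cc(Cl)cc(-c2nn(-c3cccc(NC(=O)Nc4cccc(C(F)(F)F)c4)c3)cc2-c2ccncc2)c1` has not yet been measured; it differs from compound 2 by 3-(trifluoromethyl)phenyl in place of 3,4-dichlorophenyl on an amide-type nitrogen. This change partly reverses the measured step, since trifluoromethyl returns, while a chloro is lost as well. Going by the values given here, because a number 68 percentage points higher from compound 1 to compound 2 (beyond the scatter) was large, the return of trifluoromethyl is expected to lower the number; the loss of the chloro is covered by no measured pair. Compound 3 is therefore expected to give -45% in this assay, within -80% to -5%. The expected step of a number 38 percentage points lower from compound 2 to compound 3 (beyond the scatter) points toward a stronger effect.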

Compound 3, a percentage reported as activity, at one concentration (the size of the read-out at that concentration, not a potency): -83%
Beside the measured number, compound 3's estimate is 38 percentage points above it; measured number below the stated range.
By their numbers in this assay, from the lowest: compounds 3 and 1 (each within the scatter of the next); then compound 2.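

In this assay, the step of a number 76 percentage points lower from compound 2 to compound 3 (beyond the scatter) shows that the aryl group on the amide-type nitrogen can produce a large shift even without the chloro that compound 1 carries alongside its trifluoromethyl. The step of a number 8 percentage points lower from compound 1 to compound 3 (within the scatter) replaces that chloro with hydrogen and shows no difference that can be read beyond the scatter while trifluoromethyl remains. Compound 1 and compound 3, the two with trifluoromethyl, thus stand together, apart from compound 2, although nothing measured here explains this.

The compounds shown leave open whether this result is specific to trifluoromethyl or would also hold with a nitrile, a methyl or a methoxy group in its place. They also leave open how a phenyl ring bearing only a single chloro would compare.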